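The source may report more compounds than this note shows. Statements on the series, on what has been measured and on what is new or still open speak of the compounds shown alone.

Measured compounds:

Compound 1, `O=C(CCc1nnnn1-c1cccc2ccccc12)Nc1ccccc1[N+](=O)[O-]`: in an in vitro ADME assay on microsomes from liver (Homo sapiens) for metabolic stability (on this read-out higher numbers stand for a longer-lived compound and lower numbers for a shorter-lived compound), compound 1 gives 0.117 h.
Compound 2, `CC(C)(C)c1ccc(-n2nnnc2SCC(=O)Nc2ccc(-c3ccc(OCC(=O)O)cc3)cc2Cl)c(Cl)c1`: in this assay compound 2 gives 0.117 h.
Compound 3, `CCN(C(=O)CCC(=O)Nc1ccc(-c2ccc(OCC(=O)O)cc2)cc1Cl)c1ccc(C(C)(C)C)cc1Cl`: in this assay compound 3 gives 0.1 h.

All three numbers sit close together; the value of compound 3 lies within the usual scatter of both compound 1 and compound 2, so no one of the three can be called longer- or shorter-lived than the others on this evidence. None of the pairs differs in a single place, so no single structural step can be read off from the measured set.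

Compound 4, `CC(C)(C)c1ccc(N(C(=O)CCC(=O)Nc2ccc(-c3ccc(OCC(=O)O)cc3)cc2Cl)C2CC2)c(Cl)c1`, has not yet been measured. It differs from compound 3 in one place: cyclopropyl in place of ethyl on an amide-type nitrogen, the rest of the molecule unchanged. Among the compounds with values here, with no measured step of this kind among the three compounds, the expectation in this assay is for no step beyond the scatter, in either direction. Compound 4 is therefore expected to give about 0.12 h, in a range from 0.06 h to 0.25 h. This expectation means a step of a 1.2-fold higher number from compound 3 to compound 4 (0.08 log units; within the scatter), which is within the scatter.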

Compound 4, half-life: 0.25 h
Beside the measured number, compound 4's estimate is 2.1-fold (0.32 log units) below it; low and high end bracket the measured number.
By their numbers in this assay, from the lowest: compounds 3, 1 and 2 (each within the scatter of the next); then compound 4.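

In this assay, placing cyclopropyl instead of ethyl on the amide-type nitrogen gives a 2.5-fold higher number from compound 3 to compound 4 (0.40 log units; beyond the scatter), and this step lies beyond the scatter. Within the data shown here, it is the first change in the set that can be read at a single place, since the rest of the molecule stays the same. It shows that the half-life responds to the group on this nitrogen, even when the change is as small as replacing ethyl with a three-membered ring of carbon only, but nothing at hand explains this step.

The compounds shown leave open whether the ring itself matters or any group of similar size would do, a question that a propyl chain or an isopropyl group on this nitrogen could address. A cyclobutyl ring or a plain hydrogen at this place would show how far the trend extends in either direction.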